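Removing a Methyl from the Pyrazole: Expected Oral Exposure

The compounds below may be only part of what the source reports. "The series", "measured", "known", "first", "only" and "open" are said of these compounds alone.

Measured so far:
compound 1 `CN1CCC(S(=O)(=O)c2ccc3nc(NC(=O)NC(=O)c4cc(N5CCCC5)ccc4Cl)sc3c2)CC1`: 5800 nM
compound 2 `Cc1ccnn1-c1ccc(Cl)c(C(=O)NC(=O)Nc2nc3ccc(S(=O)(=O)C4CCN(C)CC4)cc3s2)c1`: 640 nM

In an ADME assay on the whole organism (strain CD1) for pharmacokinetics, with Mus musculus as the target, read by LC-MS, at a dose of 2 mg/kg by the oral route (on this read-out higher numbers stand for higher exposure at the dose given and lower numbers for lower exposure), compound 2 stands at the lower of the two numbers, with compound 1 above it by the step of a 9.1-fold lower number from compound 1 to compound 2 (0.96 log units; beyond the scatter). Compound 3 `CN1CCC(S(=O)(=O)c2ccc3nc(NC(=O)NC(=O)c4cc(-n5cccn5)ccc4Cl)sc3c2)CC1` is not yet measured. It differs from compound 2 by hydrogen in place of methyl on an aromatic carbon. Among the compounds with values here, no measured step follows this same change; the only one seen swaps a whole ring, so it offers no direct guide. Compound 3 is therefore expected to land close to compound 2, within the usual scatter, as the step of a 1.1-fold higher number from compound 2 to compound 3 (0.04 log units; within the scatter). The estimate for compound 3 is 700 nM, with a range from 250 nM to 2000 nM.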

Compound 3, maximal plasma concentration: 1500 nM
Beside the measured number, compound 3's estimate is 2.1-fold (0.33 log units) below it; measured number inside the range.
By their numbers in this assay, from the lowest: compound 2; then compound 3; then compound 1.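

In this assay, hydrogen in place of methyl gives a 2.3-fold higher number from compound 2 to compound 3 (0.37 log units; beyond the scatter), so a single methyl, next to the ring atom that bears a large group, is enough to shift oral exposure. The unsubstituted 1H-pyrazol-1-yl still falls short of pyrrolidin-1-yl, with a 3.9-fold lower number from compound 1 to compound 3 (0.59 log units; beyond the scatter), so removing the methyl recovers only part of the gap between those two rings. Nothing available here explains this shift. As far as these compounds go, how an ethyl group, a chlorine atom or an amine on this same carbon would compare stays open.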